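The source may hold more compounds than are shown below. What is called first, only, known or untested is meant among the compounds shown, and "the series" means these compounds.

Working notes on the series. Going by the values given here, in a functional assay on PC-3 cells (Homo sapiens) for antiproliferative activity, read by MTT assay, with a stated time of 48 h (a lower number here means a stronger inhibitor, a higher number a weaker inhibitor), compound 3 `O=C1c2ccc(F)cc2C(=O)N1c1nc(-c2ccccc2)cs1` gives 40200 nM, the second highest of the three numbers so far; compound 2 `O=C1c2ccccc2C(=O)N1c1nc(-c2ccc(F)cc2)cs1` gives 37200 nM and compound 1 `O=C1c2ccccc2C(=O)N1c1nc(-c2ccccc2)cs1` gives 43900 nM, and all three sit within the scatter of one another. Compound 4 `O=C1c2ccc(F)cc2C(=O)N1c1nc(-c2ccc(F)cc2)cs1` differs from compound 3 by fluoro in place of hydrogen on an aromatic carbon. The same change on the phenyl ring has already been measured once, as a 1.2-fold lower number from compound 1 to compound 2 (0.07 log units; within the scatter), and the other fluoro substitution, on the shared core, gave a 1.1-fold lower number from compound 1 to compound 3 (0.04 log units; within the scatter); both steps lie within the scatter. No step beyond the scatter is therefore expected for compound 4, estimated as a 1.1-fold lower number from compound 3 to compound 4 (0.06 log units; within the scatter). The expected value for compound 4 in this assay is 35000 nM, with a range from 18000 nM to 70000 nM.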

Compound 4, half-maximal inhibitory concentration: 39500 nM
Compound 4: middle estimate off by 1.1-fold (0.05 log units), on the low side, within the range that was stated.
By their numbers in this assay, from the lowest: compounds 2, 4, 3 and 1 (each within the scatter of the next).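

In this assay the change from phenyl to 4-fluorophenyl now reads on a second core, as a 1.0-fold lower number from compound 3 to compound 4 (0.01 log units; within the scatter), and the fluoro on the shared core reads with the 4-fluorophenyl group present, as a 1.1-fold higher number from compound 2 to compound 4 (0.03 log units; within the scatter). The phenyl change stays within the scatter whether or not the core carries fluoro: the same change on two cores in this assay, a 1.2-fold lower number (0.07 log units; within the scatter) from compound 1 to compound 2 and a 1.0-fold lower number (0.01 log units; within the scatter) from compound 3 to compound 4, 1.2-fold (0.06 log units) apart, within the scatter of two such steps The core change likewise stays within the scatter with either phenyl or 4-fluorophenyl: the same change on two cores in this assay, a 1.1-fold lower number (0.04 log units; within the scatter) from compound 1 to compound 3 and a 1.1-fold higher number (0.03 log units; within the scatter) from compound 2 to compound 4, 1.2-fold (0.06 log units) apart, within the scatter of two such steps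

As far as these compounds go, only hydrogen and fluoro are compared at these places, so the effect of an amine or a carboxylic acid on that ring stays open. Going by these compounds alone, with no step here beyond the scatter, no structural feature can yet be tied to a change in the number.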